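This account rests on a few compounds, and the source may have more. Where it says the series, first, only, none or still open, it means among the compounds named here.

Compound 1 `CC(C)COC(=O)Nc1ccc([Se][Se]c2ccc(NC(=O)OCC(C)C)cc2)cc1`: 29000 nM
Compound 2 `CCCOC(=O)Nc1ccc([Se]C#N)cc1`: 28900 nM

Of the compounds shown here, two have been measured in a functional assay on HTB-54 cells (Homo sapiens) for cytotoxicity, read by MTT assay, with a stated time of 72 h; on this read-out lower numbers stand for stronger inhibition of growth and higher numbers for weaker inhibition of growth. Compound 1 `CC(C)COC(=O)Nc1ccc([Se][Se]c2ccc(NC(=O)OCC(C)C)cc2)cc1` gives 29000 nM, and compound 2 `CCCOC(=O)Nc1ccc([Se]C#N)cc1` gives 28900 nM. The two numbers fall within the scatter of each other, so compound 2 stands level with compound 1 rather than apart from it. The step to compound 3 `C=CCOC(=O)Nc1ccc([Se]C#N)cc1` is vinyl in place of ethyl on a saturated chain carbon bound to an oxygen next to a carbonyl group. For the measured compounds named here, no measured pair differs in only this way, so the size of this step cannot be read from another pair. Going by the values given here, since compound 1, the only other measured compound, sits within the scatter of compound 2, and the change is a small one at the end of the chain, a step confined to the scatter is expected, with no clear direction. The estimate therefore means a step of a 1.1-fold lower number from compound 2 to compound 3 (0.05 log units; within the scatter) in this assay. Compound 3 is expected to give 26000 nM, with a range from 9000 nM to 75000 nM.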

Compound 3, concentration for 50% growth inhibition: 27000 nM
Estimate against measurement, compound 3: 1.0-fold (0.02 log units) below; the measured number falls inside the stated range.
By their numbers in this assay, from the lowest: compounds 3, 2 and 1 (each within the scatter of the next).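

In this assay, the exchange of ethyl for vinyl on a saturated chain carbon bound to an oxygen next to a carbonyl group amounts to a 1.1-fold lower number from compound 2 to compound 3 (0.03 log units; within the scatter). For the compounds shown here, this is the first pair that differs in one place, and it shows that propoxy and allyloxy read alike at this position, so the double bond outside aromatic rings leaves the number within the scatter. Nothing at hand gives a reason why the two chains read alike.

The compounds shown leave open whether any group at this place moves the number beyond the scatter, such as a longer chain, a phenyl ring or an amine at the end of the chain. Going by these compounds alone, they also leave open how far the nitrile on selenium matters, since no pair isolates that group.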